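Swapping the aryl group on a sulfonyl sulfur

A few compounds are considered here, and "the series" means these few. Any claim that something is new, unique, unknown or untested is made for them only; others in the source may bear on it.

Of the compounds shown here, three sharing one core have been measured in a functional assay on PC-3 cells (Homo sapiens) for inhibition; a lower number here means a stronger inhibitor, a higher number a weaker inhibitor. Compound 1 `COc1ccc(C(=O)N2CCN(c3nc(N)c4cc(OC)c(OC)cc4n3)CC2)cc1OC` carries an amide on the ring nitrogen and gives 71000 nM. Compound 2 `COc1cc2nc(N3CCN(S(=O)(=O)c4ccc(Cl)s4)CC3)nc(N)c2cc1OC` carries a sulfonyl group instead and gives 25000 nM. Compound 3 `COc1cc2nc(N3CCN(S(=O)(=O)c4ccc([N+](=O)[O-])cc4)CC3)nc(N)c2cc1OC` keeps the sulfonyl group with a different aryl ring and gives 36000 nM. All three numbers lie within the scatter of one another, so compound 3 sits among its neighbours without a clear separation: its gap to compound 2 and its gap to compound 1 are both of a size that repeated measurements would blur.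

The unmeasured compound 4 `COc1cc2nc(N3CCN(S(=O)(=O)c4cccc(C(=O)O)c4)CC3)nc(N)c2cc1OC` differs from compound 3 in one place: 3-carboxyphenyl in place of 4-nitrophenyl on a sulfonyl sulfur. Among the compounds with values here, only one measured step bears on this kind of change, the exchange of one aryl ring for another on the same sulfonyl sulfur, and that step was a 1.4-fold higher number from compound 2 to compound 3 (0.16 log units; within the scatter). With one such step, and that one inside the scatter, there is no ground to expect a shift in this assay beyond the scatter in either direction. Compound 4 is therefore estimated at 36000 nM, with a range from 12000 nM to 100000 nM. The step this estimate implies is no change at the digits printed from compound 3 to compound 4 (within the scatter), which is expected to stay within the scatter.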

Compound 4, half-maximal inhibitory concentration: 53000 nM
The estimate for compound 4 lay 1.5-fold (0.17 log units) below the measured number; low and high end bracket the measured number.
By their numbers in this assay, from the lowest: compounds 2, 3, 4 and 1 (each within the scatter of the next, the first and the last beyond it).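

In this assay the exchange of ring on the sulfonyl sulfur gives a 1.5-fold higher number from compound 3 to compound 4 (0.17 log units; within the scatter) and so does not separate 3-carboxyphenyl from 4-nitrophenyl. Within the data shown here, the new compound does add something, since a 2.1-fold higher number from compound 2 to compound 4 (0.33 log units; beyond the scatter) is the first exchange at this place to pass beyond the scatter, if only modestly. The choice of aryl group here can therefore shift the number, but across these three sulfonyl compounds the shift is small, and compound 3 stays within the scatter of both compound 2 and compound 4. Nothing at hand bears on why the numbers fall as they do.

Still open, from the compounds shown here alone, is how a phenyl ring carrying an amine, or a plain alkyl chain set on the sulfonyl sulfur in place of an aromatic ring, would read in this assay on this core. Also open is whether any group at this place can bring the number far below the values seen so far, or whether exchanges here only produce small shifts of the kind shown.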